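This account rests on a few compounds, and the source may have more. Where it says the series, first, only, none or still open, it means among the compounds named here.

Working notes on the series. Compound 1 `CCc1ccccc1-n1cc(COc2cccc(NC(=O)Nc3ccc(Cl)c(C(F)(F)F)c3)c2)nn1`, compound 2 `O=C(Nc1cccc(OCc2cn(-c3ccc(F)cc3)nn2)c1)Nc1ccc(Cl)c(C(F)(F)F)c1` and compound 3 `O=C(Nc1cccc(OCc2cn(-c3ccc(Cl)cc3)nn2)c1)Nc1ccc(Cl)c(C(F)(F)F)c1` share one core and differ only in the group on an aromatic nitrogen. In a functional assay on HepG2 cells (Homo sapiens) for inhibition, read by MTT assay, with a stated time of 72 h (on this read-out lower numbers stand for stronger inhibition and higher numbers for weaker inhibition), compound 1 gives 3530 nM, compound 2 gives 1350 nM and compound 3 gives 2490 nM. Compound 3 stands second highest of the three numbers; its gap to compound 1 is within the scatter, and so is the step of a 1.8-fold higher number from compound 2 to compound 3 (0.27 log units; within the scatter). Compound 4 `O=C(Nc1cccc(OCc2cn(-c3ccccc3I)nn2)c1)Nc1ccc(Cl)c(C(F)(F)F)c1` has not been measured. Its change from compound 3 is 2-iodophenyl in place of 4-chlorophenyl on an aromatic nitrogen. For the measured compounds named here, two measured steps bear on this: a 1.4-fold lower number from compound 1 to compound 3 (0.15 log units; within the scatter), which exchanges 2-ethylphenyl for 4-chlorophenyl and stays within the scatter, and a 1.8-fold higher number from compound 2 to compound 3 (0.27 log units; within the scatter), a halogen exchange that also stays within the scatter. No step beyond the scatter is therefore expected in this assay, with the number more likely to drift upward than downward because compound 1 with 2-ethylphenyl gives 3530 nM. Compound 4 is estimated at 3000 nM, with a range from 1200 nM to 7500 nM, which means an expected step of a 1.2-fold higher number from compound 3 to compound 4 (0.08 log units; within the scatter).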

Compound 4, half-maximal inhibitory concentration: 2870 nM
Compound 4: the middle estimate sits 1.0-fold (0.02 log units) above what was measured; the measured number falls inside the stated range.
By their numbers in this assay, from the lowest: compounds 2, 3, 4 and 1 (each within the scatter of the next, the first and the last beyond it).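

In this assay, 2-iodophenyl in place of 4-chlorophenyl on the aromatic nitrogen leaves the number unresolved (a 1.2-fold higher number from compound 3 to compound 4 (0.06 log units; within the scatter)), so this exchange of both the halogen and the group name gives no readable change. Iodo in place of ethyl on the same aromatic ring is equally unresolved (a 1.2-fold lower number from compound 1 to compound 4 (0.09 log units; within the scatter)), so compound 4 and compound 1 cannot be told apart here. The one separation is from 4-fluorophenyl (a 2.1-fold higher number from compound 2 to compound 4 (0.33 log units; beyond the scatter)), which leaves compound 2 apart from both 2-iodophenyl and 2-ethylphenyl, while compound 3 with 4-chlorophenyl goes against any clean split by lying within the scatter of all three others.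

On these data alone, whether an unsubstituted phenyl, or a phenyl carrying an amine or a carboxylic acid, would stay in this same band remains open. The data at hand offer no explanation for these differences.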